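The source may hold more compounds than are shown below. What is called first, only, known or untested is meant among the compounds shown, and "the series" means these compounds.

Of the compounds shown here, three sharing one core have been measured in an assay for inhibition of high affinity nerve growth factor receptor (Homo sapiens), read by HTRF, with a stated time of 30 min, in the presence of a further agent that is not named here; a lower number here means a stronger inhibitor, a higher number a weaker inhibitor. Compound 1 `Cc1cc(Nc2nc(NCc3ccccc3F)nc3ccccc23)n[nH]1` gives 110 nM in this assay. Compound 2 `Cc1cc(Nc2nc(NCc3ccc(F)cc3F)nc3ccccc23)n[nH]1` gives 200 nM in this assay. Compound 3 `Cc1ccc2nc(NCc3ccc(F)cc3F)nc(Nc3cc(C)[nH]n3)c2c1` gives 110 nM in this assay. Compound 2 holds the highest of the three numbers, yet compound 1 and compound 3 each sit within the scatter of it. The step of a 1.8-fold higher number from compound 1 to compound 2 (0.26 log units; within the scatter) came from a fluoro in place of hydrogen on an aromatic carbon, and the step of a 1.8-fold lower number from compound 2 to compound 3 (0.26 log units; within the scatter) came from a methyl in place of hydrogen on an aromatic carbon of the core; neither moved beyond the scatter. Compound 4 `Cc1cc(Nc2nc(NCc3ccc(F)cc3F)nc3cc(F)ccc23)n[nH]1` has not yet been measured. It differs from compound 2 by fluoro in place of hydrogen on an aromatic carbon, that is, on a six-membered aromatic ring of carbon only within the fused two-ring core. Both measured steps, one adding a fluoro and one adding a methyl on the core, stayed within the scatter, so no movement beyond the scatter is expected in this assay. The expected step is a 1.2-fold lower number from compound 2 to compound 4 (0.07 log units; within the scatter). Compound 4 is therefore estimated at 170 nM, with a range from 70 nM to 450 nM.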

Compound 4, half-maximal inhibitory concentration: 62 nM
Compound 4: middle estimate off by 2.7-fold (0.44 log units), on the high side, outside the stated range (below it).
By their numbers in this assay, from the lowest: compounds 4, 1, 3 and 2 (each within the scatter of the next, the first and the last beyond it).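

In this assay, a fluoro on an aromatic carbon of the six-membered aromatic ring of carbon only, meta to a fused ring and para to a fused ring, gives a 3.2-fold lower number from compound 2 to compound 4 (0.51 log units; beyond the scatter) and is the first step among these compounds to lie beyond the scatter. Going by these compounds alone, the earlier changes stayed within it, with a fluoro elsewhere giving a 1.8-fold higher number from compound 1 to compound 2 (0.26 log units; within the scatter) and a methyl on the core giving a 1.8-fold lower number from compound 2 to compound 3 (0.26 log units; within the scatter), so this position is the first to show a modest response to a single added atom. Nothing given here accounts for that step.

The compounds shown leave open whether a chloro, a methoxy or an amine at this same carbon would move the number in the same direction. They also leave open whether a fluoro on the other carbons of this ring would match this step.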